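The source may report more compounds than this note shows. Statements on the series, on what has been measured and on what is new or still open speak of the compounds shown alone.

Three compounds share a core and differ in the substituent on the phenoxy ring. Compound 1 `O=c1cc(-n2cc(COc3ccccc3)nn2)c2cc(Br)ccc2o1` gives 12300 nM in a functional assay on A549 cells (Homo sapiens) for antiproliferative activity, read by MTT assay, with a stated time of 48 h; a higher number here means a weaker inhibitor, a lower number a stronger inhibitor. Compound 2 `O=c1cc(-n2cc(COc3ccc(Br)cc3)nn2)c2cc(Br)ccc2o1` gives 24500 nM in this assay, and compound 3 `O=c1cc(-n2cc(COc3ccc(F)cc3)nn2)c2cc(Br)ccc2o1` gives 850 nM in this assay, the lowest of the three. The change from compound 2 to compound 3 is fluoro in place of bromo on an aromatic carbon, and that step was a 29-fold lower number from compound 2 to compound 3 (1.46 log units; beyond the scatter). The change from compound 2 to compound 1 is hydrogen in place of bromo on an aromatic carbon, with a step of a 2.0-fold lower number from compound 2 to compound 1 (0.30 log units; within the scatter). Compound 4 `O=c1cc(-n2cc(COc3ccc(F)cc3)nn2)c2ccccc2o1` has not been measured; it differs from compound 3 by hydrogen in place of bromo on an aromatic carbon. This is the same kind of change as that from compound 2 to compound 1, but the place differs: there the hydrogen entered on the phenoxy ring para to a large group, here it enters on the fused core ring. Because the earlier step of a 2.0-fold lower number from compound 2 to compound 1 (0.30 log units; within the scatter) was small, a step of a 1.8-fold higher number from compound 3 to compound 4 (0.25 log units; within the scatter) in this assay is expected for compound 4. Compound 4 is therefore estimated at 1500 nM in this assay, with a range of 400 nM to 6000 nM.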

Compound 4, half-maximal inhibitory concentration: 680 nM
Beside the measured number, compound 4's estimate is 2.2-fold (0.34 log units) above it, and the stated range covers the measured number.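

In this assay, hydrogen in place of bromo on the fused ring gives a 1.3-fold lower number from compound 3 to compound 4 (0.10 log units; within the scatter), and this step does not differ from the one seen earlier on the phenoxy ring: the same change on two cores in this assay, a 2.0-fold lower number (0.30 log units; within the scatter) from compound 2 to compound 1 and a 1.3-fold lower number (0.10 log units; within the scatter) from compound 3 to compound 4, 1.6-fold (0.20 log units) apart, within the scatter of two such steps In these two pairs, then, the change carried from one setting to the other with no clear effect on the number. Among these compounds, it does not show a general rule, since it rests on only two pairs, the bromo leaves a different ring in each, and both steps are small.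

The compounds shown leave open whether the large step seen with fluoro, a 14-fold lower number from compound 1 to compound 3 (1.16 log units; beyond the scatter), would recur on the core of compound 4. They also leave open what an amine or a carboxylic acid on the phenoxy ring would do.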